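The compounds below may be only part of what the source reports. "The series", "measured", "known", "first", "only" and "open" are said of these compounds alone.

Notes on the series: in a functional assay on BXPC-3 cells (Homo sapiens) for antiproliferative activity, read by MTT assay, with a stated time of 24 h (on this read-out lower numbers stand for stronger inhibition and higher numbers for weaker inhibition), compound 1 (`CCn1c(C(=O)N[C@@H](C)CO)ccc1C(CC)(CC)c1ccc(OCS(=O)(=O)c2ccccc2)c(C)c1`) gives 15300 nM and compound 2 (`CCn1c(C(=O)NC(C)(C)CO)ccc1C(CC)(CC)c1ccc(OCS(=O)(=O)c2ccccc2)c(C)c1`) gives 18300 nM so these two values lie within the scatter of each other and compound 2 holds no separate rank. Compound 3 (`CCn1c(C(=O)NC2(CO)CC2)ccc1C(CC)(CC)c1ccc(OCS(=O)(=O)c2ccccc2)c(C)c1`) differs from compound 2 in one place, on an amide-type nitrogen: 1-(hydroxymethyl)cyclopropyl in place of 1-(hydroxymethyl)-1-methylethyl on an amide-type nitrogen with 1-(hydroxymethyl)cyclopropyl in place of 1-(hydroxymethyl)-1-methylethyl. Among the compounds with values here, one measured step bears on this place, a 1.2-fold higher number from compound 1 to compound 2 (0.08 log units; within the scatter) and it is small. Within the data shown here, that step is a different change, and no measured compound carries the three-membered ring. No step beyond the scatter is therefore expected in this assay in either direction. The expected size is a 1.1-fold lower number from compound 2 to compound 3 (0.06 log units; within the scatter) and nothing more is claimed for it. For compound 3 the estimated value is 16000 nM with an expected range from 7500 nM to 34000 nM in this read-out.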

Compound 3, half-maximal inhibitory concentration: 45400 nM
For compound 3 the middle estimate is 2.8-fold (0.45 log units) below the measured one; measured number above the stated range.
By their numbers in this assay, from the lowest: compounds 1 and 2 (each within the scatter of the next); then compound 3.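

In this assay the substituent on the amide-type nitrogen now matters: the change to 1-(hydroxymethyl)cyclopropyl from 1-(hydroxymethyl)-1-methylethyl gives a 2.5-fold higher number from compound 2 to compound 3 (0.39 log units; beyond the scatter) and lies beyond the scatter, with the heavy-atom, donor and acceptor counts unchanged. The change to the same group from 1-(hydroxymethyl)ethyl gives a 3.0-fold higher number from compound 1 to compound 3 (0.47 log units; beyond the scatter) and also lies beyond the scatter, while the two open-chain groups remain within the scatter of each other, so among these three only the three-membered ring stands apart. No measurement at hand accounts for this step. The compounds shown cannot tell whether the step is specific to the three-membered ring, as they include no 1-(hydroxymethyl)cyclobutyl group. Going by these compounds, it also remains open how this position responds when an amine or a carboxylic acid replaces the hydroxymethyl.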